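Ester variation on a hydroxypropyl adenine scaffold: cytotoxicity notes

The source may report more compounds than this note shows. Statements on the series, on what has been measured and on what is new or still open speak of the compounds shown alone.

Measured so far:
compound 1 `CCCCCOC(=O)C(O)Cn1cnc2c(N)ncnc21`: 200 ug/mL
compound 2 `CCCOC(=O)C(O)Cn1cnc2c(N)ncnc21`: 100 ug/mL
compound 3 `CCC(C)OC(=O)C(O)Cn1cnc2c(N)ncnc21`: > 400 ug/mL

In a functional assay on PRK cells (Oryctolagus cuniculus) for cytotoxicity (a lower number here means that less compound is tolerated, a higher number that more compound is tolerated), compound 1 gives 200 ug/mL and compound 2 gives 100 ug/mL. The step of a 2.0-fold lower number from compound 1 to compound 2 (0.30 log units; within the scatter) arises from hydrogen in place of ethyl on a saturated chain carbon, three bonds along the chain from an oxygen next to a carbonyl group. For compound 3 the value is a limit of the assay, not a number: the limit of > 400 ug/mL in this assay, at which 1 of the 3 values shown sits. Compound 3 differs from compound 1 by sec-butyl in place of pentyl on an oxygen next to a carbonyl group.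

Compound 4 `CCOC(=O)C(O)Cn1cnc2c(N)ncnc21` is not yet measured. It differs from compound 3 by hydrogen in place of ethyl on a saturated chain carbon bound to an oxygen next to a carbonyl group and a saturated chain carbon, the same kind of change as from compound 1 to compound 2, though the place differs: there on a saturated chain carbon, three bonds along the chain from an oxygen next to a carbonyl group; here on a saturated chain carbon bound to an oxygen next to a carbonyl group and a saturated chain carbon. Beside the earlier step, a step of an at least 2.0-fold lower number from compound 3 to compound 4 (0.30 log units; that floor lies within the scatter) is expected, resting on a 2.0-fold lower number from compound 1 to compound 2 (0.30 log units; within the scatter). Compound 4 is estimated at 200 ug/mL in this assay, between 100 ug/mL and 400 ug/mL.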

Compound 4, minimum cytotoxic concentration: > 400 ug/mL
Compound 4: a limit, no number; the forecaster's own chance of this, stated with the estimate: 25%; middle value at least 2.0-fold (0.30 log units) from the limit.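

In this assay compound 4 gives > 400 ug/mL as a limit and not a number, and compound 3 stands at that same limit: the limit of > 400 ug/mL in this assay, at which 2 of the 4 values shown sit. The step between these two compounds cannot be read, so hydrogen in place of ethyl at this place cannot be set against the same kind of change from the pentyl ester, which gave a 2.0-fold lower number from compound 1 to compound 2 (0.30 log units; within the scatter) and which is therefore neither confirmed nor contradicted as transferable. What can be read is an at least 4.0-fold higher number from compound 2 to compound 4 (0.60 log units; beyond the scatter) and an at least 2.0-fold higher number from compound 1 to compound 4 (0.30 log units; that floor lies within the scatter) but these are changes of a different kind and say nothing on transfer.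

On these data alone, the true values of compound 3 and compound 4 remain open. So does the reading for a longer chain or a carboxylic acid in place of the ester.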